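Diarylurea series: anilino variation and cell inhibition

A few compounds are considered here, and "the series" means these few. Any claim that something is new, unique, unknown or untested is made for them only; others in the source may bear on it.

Measured so far:
Compound 1, `Cc1ccc(Nc2cc(NC(=O)Nc3c(Cl)cccc3Cl)ncn2)cc1F`, gives 45.3%.
Compound 2, `Cc1cc(F)cc(Nc2cc(NC(=O)Nc3c(Cl)cccc3Cl)ncn2)c1`, gives 65.1%.

In a functional assay on NCI-H1581 cells (Homo sapiens) for inhibition, read by MTT assay, with a stated time of 48 h, tested at 10 uM (a lower number here means less inhibition, a higher number more inhibition at the concentration tested (going by the name of the read-out)), compound 2 stands highest of the two numbers shown, and its nearest neighbour is compound 1, a step of a number 19.8 percentage points higher from compound 1 to compound 2 (beyond the scatter). For the measured compounds named here, that is the only measured step, and it exchanges one fluoro-methylphenyl for another on a nitrogen on an aromatic ring.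

Compound 3, `COc1cc(Br)ccc1Nc1cc(NC(=O)Nc2c(Cl)cccc2Cl)ncn1`, awaits measurement in this assay. The change from compound 2 is 4-bromo-2-methoxyphenyl in place of 3-fluoro-5-methylphenyl on a nitrogen on an aromatic ring. Going by the values given here, no measured pair covers the entry of a bromine or a methoxy group, so the step from compound 1 to compound 2 bears on it only as a sign that the aryl group on this nitrogen can shift the read-out beyond the scatter in either direction. Among the compounds with values here, compound 3 is therefore expected to land near the middle of the two known numbers, with a step of a number 13.1 percentage points lower from compound 2 to compound 3 (beyond the scatter), and the estimate is 52%, within 25% to 78%.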

Compound 3, a percentage reported as inhibition, at one concentration (the size of the read-out at that concentration, not a potency): 47.3%
Estimate against measurement, compound 3: 4.7 percentage points above, within the range that was stated.
By their numbers in this assay, from the lowest: compounds 1 and 3 (each within the scatter of the next); then compound 2.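

In this assay the step to a bromine- and methoxy-bearing aryl group on this nitrogen is a number 17.8 percentage points lower from compound 2 to compound 3 (beyond the scatter), with 4-bromo-2-methoxyphenyl in place of 3-fluoro-5-methylphenyl. Set against 3-fluoro-4-methylphenyl, the same group gives a number 2 percentage points higher from compound 1 to compound 3 (within the scatter), so two aryl groups with quite different substituents cannot be separated here, and among the three compounds only compound 2 stands apart from the others. Nothing available bears on the reason for either step.

As far as these compounds go, compound 3 brings in the bromine and the methoxy group together, so the share of each in the step remains open. Also open, from the compounds shown here alone, is how this position would read with a dimethylamino group or a carboxylic acid on the aryl ring.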